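This account rests on a few compounds, and the source may have more. Where it says the series, first, only, none or still open, it means among the compounds named here.

Compound 1 `Clc1ccc(/C=N/c2sc3c(c2-c2nc4ccccc4s2)CCCC3)c(Cl)c1`: 542 ug/mL
Compound 2 `C(=C/c1ccccc1)\C=N\c1sc2c(c1-c1nc3ccccc3s1)CCCC2`: 389 ug/mL

Both compounds were tested in an ADME assay on HeLa cells (Homo sapiens) for cytotoxicity, read by MTT assay, with a stated time of 72 h; on this read-out higher numbers stand for lower toxicity in this test and lower numbers for higher toxicity in this test. They share a core and differ only in the group on the carbon that carries a double bond to nitrogen, and that single measured step, a 1.4-fold lower number from compound 1 to compound 2 (0.14 log units; within the scatter), lies within the scatter. On these two numbers compound 2 therefore does not stand apart from compound 1; the two are, for practical purposes, alike in this assay.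

Compound 3 `Clc1ccc2sc(-c3c(/N=C/C=C/c4ccccc4)sc4c3CCCC4)nc2c1` keeps the 2-phenylethenyl group of compound 2 and differs from it in one place: chloro in place of hydrogen on an aromatic carbon. For the measured compounds named here, no measured step touches this ring or this kind of change, so nothing among the measured compounds speaks directly to it. Going by the values given here, the only step at hand, the exchange at the carbon with the double bond to nitrogen from compound 1 to compound 2, stayed within the scatter and concerns another part of the molecule.

Among the compounds with values here, with no bearing step to lean on, the expected change in this assay from compound 2 to compound 3 is no change at the digits printed from compound 2 to compound 3 (within the scatter), that is, none beyond the scatter. Compound 3 is accordingly estimated at 389 ug/mL, with a range from 190 ug/mL to 780 ug/mL.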

Compound 3, half-maximal cytotoxic concentration: 150 ug/mL
Beside the measured number, compound 3's estimate is 2.6-fold (0.41 log units) above it; measured number below the stated range.
By their numbers in this assay, from the lowest: compound 3; then compounds 2 and 1 (each within the scatter of the next).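

This is the first change among the compounds shown to move the number beyond the scatter: in this assay, chloro in place of hydrogen on an aromatic carbon gives a 2.6-fold lower number from compound 2 to compound 3 (0.41 log units; beyond the scatter). A lower number here stands for higher toxicity in this test. The step is thus a modest shift towards greater toxicity, and it shows that this six-membered aromatic ring of carbon only, part of a fused system, is not a silent part of the molecule in this test, even for a change of a single heavy atom. Nothing available explains the shift, so the result remains an observation from one pair of compounds.

The compounds shown leave open whether another group on this same aromatic carbon, such as fluoro, methoxy or an amine, would move the number as chloro does, or in the opposite direction. They also leave open whether chloro would have a similar effect on the other aromatic carbons of this ring, or with the 2,4-dichlorophenyl group of compound 1 in place of 2-phenylethenyl.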